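From a Difluorophenyl Ketone to a Methoxyphenyl Ketone

The source may hold more compounds than are shown below. What is called first, only, known or untested is meant among the compounds shown, and "the series" means these compounds.

Of the compounds shown here, three that share one core have been measured in a functional assay on WI-38 VA13 cells (Homo sapiens) for cytotoxicity; a higher number here means that more compound is needed for the effect, a lower number that less compound is needed. Compound 1 `COc1ccc(CCOC(=O)c2oc3cc(-c4ccccc4)cc(O)c3c2C)cc1OC` gives 0.021 ug/mL, and compound 3 `COc1ccc(CCOC(=O)c2oc3cc(-c4ccccc4)cc(O)c3c2C)cc1` gives 0.02 ug/mL; the step from compound 1 to compound 3, hydrogen in place of methoxy on an aromatic carbon, amounts to a 1.1-fold lower number from compound 1 to compound 3 (0.02 log units; within the scatter). Compound 2 `Cc1c(C(=O)c2ccc(F)c(F)c2)oc2cc(-c3ccccc3)cc(O)c12`, a ketone rather than an ester, gives 0.4 ug/mL, the highest of the three numbers and well beyond the scatter from both compound 1 and compound 3.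

Compound 4 `COc1ccccc1C(=O)c1oc2cc(-c3ccccc3)cc(O)c2c1C` differs from compound 2 by 2-methoxyphenyl in place of 3,4-difluorophenyl on a carbonyl carbon. For the measured compounds named here, no measured step touches the aryl group on the carbonyl carbon. Going by the values given here, the only measured step, a 1.1-fold lower number from compound 1 to compound 3 (0.02 log units; within the scatter), concerns a methoxy elsewhere in the molecule and lay within the scatter, so it offers no direction. With nothing pointing either way, the step expected from compound 2 to compound 4 in this assay is a 1.1-fold higher number from compound 2 to compound 4 (0.05 log units; within the scatter), that is, no change beyond the scatter. Compound 4 is therefore expected to give about 0.45 ug/mL in this assay, within a range from 0.12 ug/mL to 1.6 ug/mL.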

Compound 4, half-maximal effective concentration: 0.09 ug/mL
Compound 4: middle estimate off by 5.0-fold (0.70 log units), on the high side, outside the stated range (below it).
By their numbers in this assay, from the lowest: compounds 3 and 1 (each within the scatter of the next); then compound 4; then compound 2.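

Compound 2 and compound 4 show that the aryl group on a carbonyl carbon is not a silent place in the series: in this assay, 2-methoxyphenyl in place of 3,4-difluorophenyl gives a 4.4-fold lower number from compound 2 to compound 4 (0.65 log units; beyond the scatter), a step beyond the scatter. For the compounds shown here, the only earlier step, a 1.1-fold lower number from compound 1 to compound 3 (0.02 log units; within the scatter), lay within the scatter and concerned a methoxy elsewhere in the molecule, so it gave no sign that a single change could move this number. The two aryl groups have the same count of heavy atoms, and they differ in their substituents, with the entering group carrying one hydrogen-bond acceptor and the leaving group none.

Because both fluorines leave as the methoxy enters, the compounds shown cannot separate the two changes, and the effect of a plain phenyl or an aminophenyl on the carbonyl carbon stays open. Nothing measured here accounts for the step.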